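Trimming the cyclohexyl ether on a bis-chromone scaffold

The source may report more compounds than this note shows. Statements on the series, on what has been measured and on what is new or still open speak of the compounds shown alone.

Compound 1 `O=c1c(Cc2coc3cccc(OCC4CCCCC4)c3c2=O)coc2ccccc12` is the reference point. Among the measured compounds shown here, in a functional assay on PC-3 cells (Homo sapiens) for antiproliferative activity, read by XTT assay (a higher number here means a weaker inhibitor, a lower number a stronger inhibitor), compound 1 gives 4510 nM, the only actual number among the two compounds measured so far. Compound 2 `O=c1c(Cc2coc3cccc(OCC4CCCCC4)c3c2=O)coc2cc(Cl)ccc12` carries a chloro in place of hydrogen on an aromatic carbon. For compound 2 the result in this assay is a limit, > 10000 nM, and not a number. The step of an at least 2.2-fold higher number from compound 1 to compound 2 (0.34 log units; beyond the scatter) rests on (the limit of > 10000 nM in this assay, at which 1 of the 2 values shown sits).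

Compound 3 `CC(C)COc1cccc2occ(Cc3coc4ccccc4c3=O)c(=O)c12` differs from compound 1 at a different place: isopropyl in place of cyclohexyl on a saturated chain carbon bound to an oxygen on an aromatic ring. For the measured compounds named here, no measured step touches this saturated chain carbon bound to the ether oxygen; the single measured step concerns the aromatic ring and says nothing about the ether substituent. The expectation for compound 3 therefore leans on compound 1 alone and on the size of the group that is removed. A step of a 1.4-fold higher number from compound 1 to compound 3 (0.16 log units; within the scatter) is expected, anchored only on compound 1 and its value 4510 nM. The estimated value of compound 3 in this assay is 6500 nM, expected to fall between 2500 nM and 16000 nM.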

Compound 3, half-maximal inhibitory concentration: 1720 nM
Beside the measured number, compound 3's estimate is 3.8-fold (0.58 log units) above it, outside the stated range (below it).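

Among the compounds shown here, the ether substituent turns out to be a place to which this assay responds, and the response runs toward a stronger inhibitor: the change gives a 2.6-fold lower number from compound 1 to compound 3 (0.42 log units; beyond the scatter), whereas the only earlier step, on the aromatic ring, ran toward a weaker one. Cyclohexyl is therefore not needed for the activity of this series, since isopropyl, with no ring and 3 heavy atoms in place of 6, does better on the same core, although this rests on a single pair of compounds. Nothing in the data shown accounts for why the smaller group gives the lower number.

As far as these compounds go, it remains open whether the trend continues to a smaller group such as methyl or cyclopropyl, or whether a longer chain such as hexyl, or a chain ending in an amine or a carboxylic acid, would hold the gain. From the compounds shown here alone, it is also open whether chloro on the aromatic ring would weaken compound 3 as it weakened compound 1, as the two changes appear here only separately.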